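Ring-closed amine at the sulfur of compound 1

A few compounds are considered here, and "the series" means these few. Any claim that something is new, unique, unknown or untested is made for them only; others in the source may bear on it.

Compound 1 `CC(C)c1n[nH]c2c(NCc3ccc(-c4ccccn4)cc3)nc(SCC(O)CN)nc12` gives 55 nM in a functional assay on HT cells (Homo sapiens) for antiproliferative activity, read by fluorescence, with a stated time of 72 h (on this read-out higher numbers stand for weaker inhibition of growth and lower numbers for stronger inhibition of growth), the lowest of the three numbers recorded. Compound 2 `CC(C)c1n[nH]c2c(NCc3ccc(-c4ccccn4)cc3)nc(SC3CCCCC3O)nc12` gives 636 nM, and compound 3 `C=CCSc1nc(NCc2ccc(-c3ccccn3)cc2)c2[nH]nc(C(C)C)c2n1` gives 1010 nM. Compound 4 `CC(C)c1n[nH]c2c(NCc3ccc(-c4ccccn4)cc3)nc(SC3CCCCC3N)nc12` differs from compound 1 in one place: 2-aminocyclohexyl in place of 3-amino-2-hydroxypropyl on a sulfur. Among the compounds with values here, two measured steps bear on this. The step of a 12-fold higher number from compound 1 to compound 2 (1.06 log units; beyond the scatter) puts a hydroxy-bearing six-membered ring on the sulfur, and the step of an 18-fold higher number from compound 1 to compound 3 (1.26 log units; beyond the scatter) removes both the amine and the hydroxyl. Compound 4 keeps an amine but gives up the hydroxyl and adopts the ring, so a higher number is expected, of about a 5.5-fold higher number from compound 1 to compound 4 (0.74 log units; beyond the scatter), though it may be held a little below the step seen in compound 2. Compound 4 is therefore estimated at 300 nM, with a range of 100 nM to 1200 nM.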

Compound 4, concentration for 50% growth inhibition: 139 nM
Compound 4: the middle estimate sits 2.2-fold (0.33 log units) above what was measured; low and high end bracket the measured number.
By their numbers in this assay, from the lowest: compound 1; then compound 4; then compounds 2 and 3 (each within the scatter of the next).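

In this assay, the ring itself is tolerated on the sulfur when it carries an amine: 2-aminocyclohexyl in place of 3-amino-2-hydroxypropyl gives only a 2.5-fold higher number from compound 1 to compound 4 (0.40 log units; beyond the scatter). Amino in place of hydroxy on that ring gives a 4.6-fold lower number from compound 2 to compound 4 (0.66 log units; beyond the scatter), and 2-aminocyclohexyl in place of allyl gives a 7.3-fold lower number from compound 3 to compound 4 (0.86 log units; beyond the scatter), so among these compounds the amine goes with the lower numbers. No measurement shown accounts for these differences.

From the compounds shown here alone, whether a ring bearing both an amine and a hydroxyl would recover the number of compound 1 stays open. So does the effect of a piperidine or a carboxylic acid at this sulfur.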